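Swapping cyclohexyl for benzyl on a tetrazole-bearing hydroxamate

This account rests on a few compounds, and the source may have more. Where it says the series, first, only, none or still open, it means among the compounds named here.

Four compounds share a hydroxamic acid head attached to a benzene ring, with a tetrazole carrying a variable group on one of its nitrogens. Compound 1 `O=C(NO)c1ccc(CN(Cc2nnnn2C2CCCCC2)C(=O)c2ccccc2)cc1` and compound 2 `O=C(NO)c1ccc(CN(Cc2nnnn2Cc2ccccc2)C(=O)c2ccccc2)cc1` hold the tetrazole through an amide-bearing linker, while compound 3 `O=C(NO)c1ccc(CNC(c2ccccc2)c2nnnn2C2CCCCC2)cc1` and compound 4 `O=C(NO)c1ccc(CNC(c2ccccc2)c2nnnn2Cc2ccccc2)cc1` join it through an amine. The difference between the two cores is not broken down here.

In an assay on isolated protein for inhibition of protein deacetylase HDAC6 (Homo sapiens), read by fluorescence, with a stated time of 90 min (on this read-out higher numbers stand for weaker inhibition and lower numbers for stronger inhibition), compound 1 gives 70 nM and compound 2 gives 30 nM. The change between them, (benzyl in place of cyclohexyl on an aromatic nitrogen), brings a 2.3-fold lower number from compound 1 to compound 2 (0.37 log units; beyond the scatter). Compound 3 in this assay gives 120 nM, which sits close to compound 1 and is the highest of the three measured numbers.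

Compound 4 differs from compound 3 by the same change, (benzyl in place of cyclohexyl on an aromatic nitrogen), made on the other core. Since the only measured example of this change is the step from compound 1 to compound 2, shown as a 2.3-fold lower number from compound 1 to compound 2 (0.37 log units; beyond the scatter), the expectation is that compound 4 will show a step of similar size, estimated as a 2.2-fold lower number from compound 3 to compound 4 (0.34 log units; beyond the scatter) in this assay. This rests on a single precedent, so the range is kept wide. In this assay compound 4 is therefore expected to give about 55 nM, with an estimated span from 25 nM to 130 nM.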

Compound 4, half-maximal inhibitory concentration: 100 nM
Compound 4: middle estimate off by 1.8-fold (0.26 log units), on the low side; the range from low to high includes it.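

In this assay, putting benzyl in place of cyclohexyl on the core of compound 3 gives a 1.2-fold lower number from compound 3 to compound 4 (0.08 log units; within the scatter), so on this core the effect of the change cannot be told apart from the usual spread of repeated measurements. Set beside the earlier step on the core of compound 1, the new step cannot be separated from it either: the same change on two cores in this assay, a 2.3-fold lower number (0.37 log units; beyond the scatter) from compound 1 to compound 2 and a 1.2-fold lower number (0.08 log units; within the scatter) from compound 3 to compound 4, 1.9-fold (0.29 log units) apart, within the scatter of two such steps The two results therefore fit a single modest effect shared by both cores, but they equally fit an effect present on only one core, so two pairs with steps this small neither prove that the change carries from one core to the other nor show that it fails to.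

The compounds shown leave open how a smaller group such as methyl, a longer chain such as phenethyl, or a benzyl ring carrying a fluorine or a methoxy group would behave on the same tetrazole nitrogen of either core. Also open, going by these compounds, is whether a replacement that moves the number much further would carry across the two cores, a question that steps of this size cannot settle.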